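A few compounds are considered here, and "the series" means these few. Any claim that something is new, unique, unknown or untested is made for them only; others in the source may bear on it.

Working notes on the series. In a functional assay (aorta) with Rattus norvegicus as the target (on this read-out higher numbers stand for higher potency (the scale is a negative logarithm) and lower numbers for lower potency), compound 1 `CCC(=O)c1ccc2c(c1)C(n1ccccc1=O)=CC(C)(C)O2` gives 6.63 and stands second highest of the three measured numbers: compound 3 `CC1(C)C=C(n2ccccc2=O)c2cc(C(=O)c3ccccc3C(F)(F)F)ccc2O1` gives 6.76, and compound 2 `CC1(C)C=C(n2ccccc2=O)c2cc(C(=O)c3ccccc3[N+](=O)[O-])ccc2O1` gives 6.17. The measured steps are a number 0.46 log units lower from compound 1 to compound 2 (beyond the scatter), a number 0.13 log units higher from compound 1 to compound 3 (within the scatter) and a number 0.59 log units higher from compound 2 to compound 3 (beyond the scatter), all of them exchanges that keep the carbonyl and its propanoyl or aryl partner in place. Going by the values given here, compound 4 `CC1(C)C=C(n2ccccc2=O)c2cc(O)ccc2O1` differs from compound 1 by hydroxy in place of propanoyl on an aromatic carbon, a change no measured step covers, since none removes the carbonyl itself. The known steps are at most modest, so a step of similar size in this assay is expected, with the direction uncertain and slightly towards lower potency given the loss of the carbonyl group. For compound 4 the estimate is 6.1, between 5.4 and 6.8, meaning an expected step of a number 0.53 log units lower from compound 1 to compound 4 (beyond the scatter).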

Compound 4, logarithm of the reciprocal of the active concentration, log(1/C): 5.44
Compound 4: the middle estimate sits 0.66 log units above what was measured, within the range that was stated.
By their numbers in this assay, from the lowest: compound 4; then compound 2; then compounds 1 and 3 (each within the scatter of the next).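

Exchanging the partner of the carbonyl across compounds 1, 2 and 3 gave steps that were modest at most, whereas removing the whole propanoyl group is a large step in this assay: a number 1.19 log units lower from compound 1 to compound 4 (beyond the scatter). This aromatic carbon therefore accepts different carbonyl partners more readily than hydroxy in place of propanoyl. Nothing available explains the loss.

The compounds shown leave open whether the carbonyl or the rest of the propanoyl group matters more, since hydroxy replaces both at once. A methoxy, an amine or a nitrile on this aromatic carbon would help separate the two.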